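The compounds below may be only part of what the source reports. "The series", "measured", "known", "first", "only" and "open" are said of these compounds alone.

Measured in a functional assay on HCT-116 cells (Homo sapiens) for antiproliferative activity, with a stated time of 72 h; on this read-out lower numbers stand for stronger inhibition and higher numbers for weaker inhibition:
Compound 1 `O=C(COc1ccc(CN2CC=C(c3c[nH]c4cccc(F)c34)CC2)c(F)c1)NO`: 1220 nM
Compound 2 `O=C(COc1ccc(CNC2CC=C(c3c[nH]c4cccc(F)c34)CC2)c(F)c1)NO`: 173 nM

Of these two, compound 1 carries the highest number and is therefore the weaker inhibitor. Compound 2 stands lower by a margin beyond the usual scatter of this assay. The next compound to be tested is compound 3 `Cc1ccc2[nH]cc(C3=CCN(Cc4ccc(OCC(=O)NO)cc4F)CC3)c2c1`, which keeps the rest of compound 1 and alters a single place: 5-methyl-1H-indol-3-yl in place of 4-fluoro-1H-indol-3-yl on a double-bonded ring carbon. The new group thus sits on the same double-bonded ring carbon as the old one. For the measured compounds named here, no measured pair shows what this exchange does, so no step beyond the scatter is predicted, in either direction. The expected change is a 1.3-fold lower number from compound 1 to compound 3 (0.11 log units; within the scatter), a small shift that would lie within the scatter. For compound 3 the estimated value is 950 nM, with an expected range of 320 nM to 2800 nM.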

Compound 3, half-maximal inhibitory concentration: 1450 nM
Beside the measured number, compound 3's estimate is 1.5-fold (0.18 log units) below it, within the range that was stated.
By their numbers in this assay, from the lowest: compound 2; then compounds 1 and 3 (each within the scatter of the next).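

In this assay, placing 5-methyl-1H-indol-3-yl on the double-bonded ring carbon in place of 4-fluoro-1H-indol-3-yl gives a 1.2-fold higher number from compound 1 to compound 3 (0.08 log units; within the scatter) and so leaves the read-out unchanged within the scatter. For the compounds shown here, this is the first measured exchange at this position, and it shows that a fluorine on the indole can give way to a methyl group at a different ring position without a measurable change in this assay. Nothing measured accounts for this outcome.

The compounds shown leave open whether a larger change at this position, such as an unsubstituted 1H-indol-3-yl, a methoxy-bearing indole or a 5-carboxylic acid, would also leave the number unchanged. They also leave open whether the same exchange would be as silent on the core of compound 2.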